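One added carbonyl on a ring amine nitrogen

The compounds below may be only part of what the source reports. "The series", "measured", "known", "first", "only" and "open" are said of these compounds alone.

Measured so far:
compound 1 `O=C(CCCCN1C/C=C/CCOc2cccc(c2)-c2ccnc(n2)Nc2cccc(c2)C1)NO`: 1770 nM
compound 2 `O=C(CCCCCCN1C/C=C/COCc2cccc(c2)-c2ccnc(n2)Nc2cccc(c2)C1)NO`: 1190 nM

Both numbers come from a functional assay on NCI-H460 cells (Homo sapiens) for inhibition, read by sulforhodamine B assay, with a stated time of 48 h; a lower number here means a stronger inhibitor of growth, a higher number a weaker inhibitor of growth. Going by the values given here, compound 1 and compound 2 lie within the usual scatter of each other, so this pair gives no ranking and compound 1 stands level with the only other measured compound. The two structures also differ in more than one place, so they do not isolate any single change.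

Compound 3 `O=C(CCCCC(=O)N1C/C=C/CCOc2cccc(c2)-c2ccnc(n2)Nc2cccc(c2)C1)NO` has not yet been measured. It keeps the core of compound 1 and alters one group on an amine nitrogen in a ring, with (4-(hydroxycarbamoyl)butyl)carbonyl in place of 4-(hydroxycarbamoyl)butyl ((4-(hydroxycarbamoyl)butyl)carbonyl in place of 4-(hydroxycarbamoyl)butyl on an amine nitrogen in a ring). Among the compounds with values here, no measured pair shows this change, so the direction remains open, and the expectation in this assay is no step beyond the scatter. The anchor for that expectation is compound 1 at 1770 nM. The estimated 1.2-fold lower number from compound 1 to compound 3 (0.07 log units; within the scatter) is therefore small, though uncertain. For compound 3 the expected value is 1500 nM, with an estimated range from 500 nM to 4500 nM.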

Compound 3, concentration for 50% growth inhibition: 2250 nM
Beside the measured number, compound 3's estimate is 1.5-fold (0.18 log units) below it; measured number inside the range.
By their numbers in this assay, from the lowest: compounds 2, 1 and 3 (each within the scatter of the next).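

Going by these compounds alone, the first comparison that changes only one place on the amine nitrogen in a ring is a 1.3-fold higher number from compound 1 to compound 3 (0.10 log units; within the scatter), read in this assay, with (4-(hydroxycarbamoyl)butyl)carbonyl in place of 4-(hydroxycarbamoyl)butyl. Within the data shown here, the two earlier compounds differed in more than one place and could not show this, but this pair shows that adding a carbonyl at this nitrogen gives no step that can be told apart from ordinary repeat variation, so compound 1 and compound 3 stand level. No supporting measurement is available to explain this result.

On these data alone, this conclusion rests on a single pair, so it remains open whether a sulfonyl group in place of the carbonyl, or a longer chain bearing the same carbonyl, would also stay level with compound 1. As far as these compounds go, it is equally open whether the carbonyl would give the same result on the core of compound 2, where the ring oxygen and the chain length are both arranged differently.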